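The source may report more compounds than this note shows. Statements on the series, on what has been measured and on what is new or still open speak of the compounds shown alone.

Working notes on the series. Compound 1, `COc1ccccc1C(=O)NC(=S)NNc1ncnc2ccccc12`, is tested in a functional assay on CNE-2 cells (Homo sapiens) for cytotoxicity, read by MTT assay, with a stated time of 72 h (a lower number here means a stronger inhibitor, a higher number a weaker inhibitor), and gives 15700 nM. Against the other two measured members it sits second highest of three: compound 2, `COc1cc2ncnc(NNC(=S)NC(=O)c3ccc(C(F)(F)F)cc3)c2cc1OC`, gives 16500 nM in this assay, a gap from compound 1 that lies within the scatter, and compound 3, `COc1cc2ncnc(NNC(=S)NC(=O)c3ccccc3)c2cc1OC`, gives 8180 nM, again within the scatter of compound 1. Among the measured compounds shown here, the one single-point step among the measured compounds is a 2.0-fold lower number from compound 2 to compound 3 (0.30 log units; within the scatter), a change on the benzoyl ring that stays within the scatter.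

Compound 4, `O=C(NC(=S)NNc1ncnc2ccccc12)c1ccccc1Cl`, is not yet measured. It differs from compound 1 by chloro in place of methoxy on an aromatic carbon. For the measured compounds named here, no measured pair carries this same exchange; the step from compound 2 to compound 3 is the only neighbouring change on the same ring, and its size is within the scatter, so it offers no ground for expecting a shift. Compound 4 is therefore expected to come out close to compound 1, with a 1.1-fold lower number from compound 1 to compound 4 (0.05 log units; within the scatter) as the estimated step, not beyond the scatter. The estimated value for compound 4 in this assay is 14000 nM, with a range from 5000 nM to 40000 nM.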

Compound 4, half-maximal inhibitory concentration: 6090 nM
The estimate for compound 4 lay 2.3-fold (0.36 log units) above the measured number; the measured number falls inside the stated range.
By their numbers in this assay, from the lowest: compounds 4, 3, 1 and 2 (each within the scatter of the next, the first and the last beyond it).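

In this assay, among the compounds shown here, chloro in place of methoxy on an aromatic carbon, ortho to a large group, gives a 2.6-fold lower number from compound 1 to compound 4 (0.41 log units; beyond the scatter), the first single-place step printed as beyond the scatter, though still modest in size. For the compounds shown here, this shows that the number responds to the group at this place, at least for the pair of compound 1 and compound 4, whereas the only earlier step, a 2.0-fold lower number from compound 2 to compound 3 (0.30 log units; within the scatter), involved other groups and did not establish any such response. No measurement available for these compounds bears on the reason for the new step.

Going by these compounds alone, the single pair cannot separate what chloro adds from what the departure of methoxy removes, and a compound with hydrogen, fluoro, methyl or an amine at the same place on the core of compound 1 would begin to settle that. From the compounds shown here alone, it also remains open whether 2-methoxyphenyl to 2-chlorophenyl gives a step of similar size on the core of compound 3, or whether it holds only on the core of compound 1.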